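Replacing Cyclohexyl with 3-Methylphenyl on the Urea Nitrogen

The source may hold more compounds than are shown below. What is called first, only, known or untested is meant among the compounds shown, and "the series" means these compounds.

Compound 1 `O=C(Nc1cccc(CNc2nccnc2Cl)c1)NC1CCCCC1` carries a cyclohexyl group on one nitrogen of its urea. In a functional assay on MGC-803 cells (Homo sapiens) for antiproliferative activity, read by MTT assay, with a stated time of 48 h (on this read-out lower numbers stand for stronger inhibition and higher numbers for weaker inhibition), compound 1 gives only a limit, > 40000 nM; this is the limit of > 40000 nM in this assay, at which 1 of the 3 values shown sits, so its true potency is not known beyond that boundary. Two relatives with an aromatic ring in the same position have been measured. Compound 2 `CCc1ccc(NC(=O)Nc2cccc(CNc3nccnc3Cl)c2)c(CC)c1` gives 6130 nM in this assay, and compound 3 `O=C(Nc1cccc(CNc2nccnc2Cl)c1)Nc1ccc(F)c(Cl)c1` gives 5020 nM, the two lying close to one another.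

Among the measured compounds shown here, the one single-point comparison that touches compound 1 is an at least 7.9-fold lower number from compound 1 to compound 3 (0.90 log units; beyond the scatter); with compound 1 at the limit, the real drop could be larger still.

Compound 4 `Cc1cccc(NC(=O)Nc2cccc(CNc3nccnc3Cl)c2)c1` differs from compound 1 in one place: 3-methylphenyl in place of cyclohexyl on an amide-type nitrogen. The change again trades the saturated ring for an aromatic one, and both aromatic relatives, compound 2 and compound 3, land in the same region. A step of similar size and in the same direction is therefore expected. The expected step is an at least 5.7-fold lower number from compound 1 to compound 4 (0.75 log units; beyond the scatter). Compound 4 is estimated at 7000 nM in this assay, with a range from 2500 nM to 25000 nM.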

Compound 4, half-maximal inhibitory concentration: 14600 nM
Compound 4: the middle estimate sits 2.1-fold (0.32 log units) below what was measured, and the stated range covers the measured number.
By their numbers in this assay, from the lowest: compounds 3 and 2 (each within the scatter of the next); then compound 4. At a limit, above all of these: compound 1.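

In this assay, an aromatic ring that carries only a methyl group also gives a lower number than cyclohexyl on this urea nitrogen: an at least 2.7-fold lower number from compound 1 to compound 4 (0.43 log units; beyond the scatter). The gain over the saturated ring therefore does not need the chlorine and fluorine of the earlier 3-chloro-4-fluorophenyl group, but the groups on the aromatic ring still matter, since exchanging that group for 3-methylphenyl costs potency: a 2.9-fold higher number from compound 3 to compound 4 (0.46 log units; beyond the scatter). The full size of the gain over cyclohexyl remains unknown because compound 1 sits at a limit: the limit of > 40000 nM in this assay, at which 1 of the 4 values shown sits.

The 3-methylphenyl and 3-chloro-4-fluorophenyl groups differ in more than one substituent, so the compounds shown cannot tell whether the chlorine, the fluorine or the loss of the methyl group accounts for the step between them, and a simple 3-chlorophenyl or 4-fluorophenyl group would help to separate these. They also leave open whether an unsubstituted phenyl ring, a pyridyl ring or a methoxy group on the ring would give a lower or a higher number at this urea nitrogen.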